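Amide nitrogen methylation in a dihydroxyheptanoic acid series

The source may hold more compounds than are shown below. What is called first, only, known or untested is meant among the compounds shown, and "the series" means these compounds.

Measured compounds and values:
compound 1, `Cc1ccc(CNC(=O)c2nn(-c3ccc(F)cc3)c(CC[C@@H](O)C[C@@H](O)CC(=O)O)c2C(C)C)cc1`: 2.5 nM
compound 2, `CC(C)c1c(C(=O)N2CCC[C@H](c3ccccc3)C2)nn(-c2ccc(F)cc2)c1CC[C@@H](O)C[C@@H](O)CC(=O)O`: 2.1 nM
compound 3, `CC(C)c1c(C(=O)NCc2ccccc2)nn(-c2ccc(F)cc2)c1OC[C@@H](O)C[C@@H](O)CC(=O)O`: 3.8 nM

In an assay on microsomes from liver for inhibition of 3-hydroxy-3-methylglutaryl-coenzyme A reductase (Rattus norvegicus) (on this read-out lower numbers stand for stronger inhibition and higher numbers for weaker inhibition), compound 3 gives the largest of the three numbers, but its gaps to compound 1 and to compound 2 are both within the usual scatter, so the three compounds cannot be separated on this read-out. Among the measured compounds shown here, the only measured step, a 1.2-fold lower number from compound 1 to compound 2 (0.08 log units; within the scatter), exchanges a (4-methylbenzyl)amino group for a 3-phenylpiperidin-1-yl group on the carbonyl carbon and stays within the scatter.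

Compound 4, `CC(C)c1c(C(=O)N(C)Cc2ccccc2)nn(-c2ccc(F)cc2)c1OC[C@@H](O)C[C@@H](O)CC(=O)O`, differs from compound 3 by methyl in place of hydrogen on an amide-type nitrogen; read one bond further out, benzylamino becomes benzyl(methyl)amino. For the measured compounds named here, no measured pair shows exactly this change. Going by the values given here, the step from compound 1 to compound 2, which also replaces the hydrogen on the amide-type nitrogen as part of a larger exchange, is the nearest precedent and it is within the scatter. For compound 4 the expectation is therefore a step of a 1.2-fold higher number from compound 3 to compound 4 (0.07 log units; within the scatter), no change beyond the scatter, and compound 4 is estimated at 4.5 nM, within 1.5 nM to 14 nM.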

Compound 4, half-maximal inhibitory concentration: 5.2 nM
Beside the measured number, compound 4's estimate is 1.2-fold (0.06 log units) below it; the measured number falls inside the stated range.
By their numbers in this assay, from the lowest: compounds 2, 1, 3 and 4 (each within the scatter of the next, the first and the last beyond it).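

In this assay, among the compounds shown here, the step of a 1.4-fold higher number from compound 3 to compound 4 (0.14 log units; within the scatter) is the first reading of methyl in place of hydrogen on this amide-type nitrogen taken alone, and it stays within the scatter. The earlier step of a 1.2-fold lower number from compound 1 to compound 2 (0.08 log units; within the scatter) replaced that hydrogen only as part of a larger exchange, whereas here benzylamino becoming benzyl(methyl)amino is the sole difference, so the amide hydrogen can be replaced by methyl in compound 3 without a change beyond the scatter.

Open, as far as these compounds go, is whether a larger group on this nitrogen, such as ethyl or isopropyl, would also leave the number within the scatter. Also open, from the compounds shown here alone, is whether methyl on the amide-type nitrogen of compound 1 would give a step of similar size.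

No measurement at hand speaks to the reason for this result.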